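Amide trimming on the shared core: cyclobutyl to ethyl

A few compounds are considered here, and "the series" means these few. Any claim that something is new, unique, unknown or untested is made for them only; others in the source may bear on it.

Among the measured compounds shown here, compound 1 `CCn1c(-c2cnc(C)nc2)nc2c(N[C@H]3CCN(C(=O)C4CCC4)C3)ncnc21` and compound 2 `CCn1c(-c2ccc(C(F)(F)F)nc2)nc2c(O[C@H]3CCN(C(=O)C4CC4)C3)ncnc21` are the two measured members of this set. In a physicochemical assay for lipophilicity, read by HPLC (on this read-out higher numbers stand for higher lipophilicity and lower numbers for lower lipophilicity), compound 1 gives 1.2, and in this assay compound 2 gives 2.3. Compound 1 is thus the lower of the two numbers, with compound 2 standing above it by a gap beyond the usual scatter. The two compounds differ in several places at once, so the gap is noted only for what the two values show.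

Compound 3 `CCC(=O)N1CC[C@H](Nc2ncnc3c2nc(-c2cnc(C)nc2)n3CC)C1` is not yet measured in this assay. It differs from compound 1 in a single place: ethyl in place of cyclobutyl on a carbonyl carbon. For the measured compounds named here, with only one measured neighbour, no measured step of this kind is available to calibrate the change. A downward step of moderate size, beyond the scatter, is expected; the step of a number 0.60 log units lower from compound 1 to compound 3 (beyond the scatter) is the estimate. Compound 3 is therefore expected to give about 0.6 in this assay, within a range from 0.2 to 1.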

Compound 3, distribution coefficient: 0.7
Beside the measured number, compound 3's estimate is 0.10 log units below it, within the range that was stated.
By their numbers in this assay, from the lowest: compound 3; then compound 1; then compound 2.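

On the carbonyl carbon bound to the amide-type ring nitrogen, ethyl in place of cyclobutyl gives a number 0.50 log units lower from compound 1 to compound 3 (beyond the scatter) in this assay. Among the compounds shown here, this is the first single-place step, so the read-out at this position can now be seen apart from the other differences that blur the gap to compound 2. The change both removes the ring and shortens the group, and this one pair cannot separate the two; no measurement available here speaks to the reason for the step.

Open, on these data alone, is where a butyl chain on the same carbonyl carbon would fall relative to compound 1 and compound 3, which would help to separate ring from chain length. Also open, as far as these compounds go, is whether an amine on that chain would move the number in either direction.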